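The source may hold more compounds than are shown below. What is called first, only, known or untested is meant among the compounds shown, and "the series" means these compounds.

Compound 2 `Cn1ccc2c(Oc3ccc(NC(=O)c4cc5cccnc5n(-c5ccc(Br)cc5)c4=O)cc3F)ccnc21` holds the lowest of the two numbers measured in a functional assay on A549 cells (Homo sapiens) for antiproliferative activity, read by MTT assay, with a stated time of 72 h (on this read-out higher numbers stand for weaker inhibition and lower numbers for stronger inhibition), where compound 2 gives 390 nM; compound 1 `Cn1ccc2c(Oc3ccc(NC(=O)c4cc5cccnc5n(-c5ccccc5)c4=O)cc3F)ccnc21` gives 430 nM, and the two lie within the scatter of each other. Going by the values given here, the only step that bears on the aryl group, a 1.1-fold lower number from compound 1 to compound 2 (0.04 log units; within the scatter), shows that bromo in place of hydrogen on that ring moved nothing beyond the scatter. Compound 3 `Cn1ccc2c(Oc3ccc(NC(=O)c4cc5cccnc5n(-c5ccc(C(F)(F)F)cc5Cl)c4=O)cc3F)ccnc21` carries 2-chloro-4-(trifluoromethyl)phenyl in place of 4-bromophenyl on an aromatic nitrogen. Compound 3 is therefore expected to sit near compound 2, with a 1.1-fold lower number from compound 2 to compound 3 (0.05 log units; within the scatter) as the estimated step. For compound 3 the estimate is 350 nM, in the range 120 nM to 1000 nM.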

Compound 3, half-maximal inhibitory concentration: 3530 nM
Compound 3: middle estimate off by 10-fold (1.00 log units), on the low side; measured number outside the range, above it.
By their numbers in this assay, from the lowest: compounds 2 and 1 (each within the scatter of the next); then compound 3.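

In this assay the aryl group on the aromatic nitrogen does move the number, which the bromo step alone had not shown. 2-Chloro-4-(trifluoromethyl)phenyl gives a clear rise in place of 4-bromophenyl (a 9.1-fold higher number from compound 2 to compound 3 (0.96 log units; beyond the scatter)) and in place of phenyl (an 8.2-fold higher number from compound 1 to compound 3 (0.91 log units; beyond the scatter)), so this position does not accept every substituted phenyl alike. No measurement here offers an explanation for the rise. On these data alone, the chloro and trifluoromethyl groups enter together, so it remains open which of them carries the rise. As far as these compounds go, how a methoxy group or an amine on this ring would read also remains open.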